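The source may hold more compounds than are shown below. What is called first, only, known or untested is meant among the compounds shown, and "the series" means these compounds.

Measured compounds:
compound 1 `N=C(N)N/N=C/c1c(-c2cccs2)nc2n1CCS2` gives 17400 nM
compound 2 `Cc1cn2c(/C=N/NC(=N)N)c(-c3ccsc3)nc2s1` gives 5370 nM

Among the compounds with values here, in a functional assay on cells (Cancer cell lines, Homo sapiens) for inhibition (on this read-out lower numbers stand for stronger inhibition of growth and higher numbers for weaker inhibition of growth), compound 1 stands with the higher of the two numbers measured so far. Compound 2 gives 5370 nM, a lower number than compound 1, and the gap between the two lies beyond the usual scatter, so compound 2 inhibits growth more strongly than compound 1. The two differ in more than one place, so no single change can be credited with that gap.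

Compound 3 `N=C(N)N/N=C/c1c(-c2cc(Cl)sc2Cl)nc2n1CCS2` has not been measured. It differs from compound 1 in one place: 2,5-dichlorothiophen-3-yl in place of thiophen-2-yl on an aromatic carbon. Within the data shown here, no measured pair shows what such a change does here, so any expectation rests on weak ground. A modest step toward a lower number in this assay is expected, of size a 2.2-fold lower number from compound 1 to compound 3 (0.34 log units; beyond the scatter), about at the edge of the scatter. The value expected for compound 3 is 8000 nM, with a range from 2500 nM to 25000 nM.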

Compound 3, concentration for 50% growth inhibition: 1820 nM
For compound 3 the middle estimate is 4.4-fold (0.64 log units) above the measured one; measured number outside the range, below it.
By their numbers in this assay, from the lowest: compound 3; then compound 2; then compound 1.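

Within the data shown here, compound 1 and compound 3 differ in one place, so this pair ties a change in this assay to a single position for the first time: the aromatic carbon next to the ring nitrogen of the shared core. Putting 2,5-dichlorothiophen-3-yl in place of thiophen-2-yl there gives a 9.6-fold lower number from compound 1 to compound 3 (0.98 log units; beyond the scatter), so this position tolerates the larger group, and growth inhibition becomes stronger by more than the usual scatter. No measurement shown here explains why the number falls.

This one step joins two changes, a different attachment point on the thiophene and the two chlorine atoms, and the compounds shown do not separate them. On these data alone, how a plain thiophen-3-yl, a thiophene with one chlorine atom or a phenyl ring would behave at this position remains open.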